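Swapping the Halogenated Anilide Ring for a Bromophenyl Group

This account rests on a few compounds, and the source may have more. Where it says the series, first, only, none or still open, it means among the compounds named here.

Of the compounds shown here, three built on one shared core have been tested in a functional assay on MDA-MB-231 cells (Homo sapiens) for cytotoxicity, read by MTT assay, with a stated time of 72 h; on this read-out lower numbers stand for stronger inhibition and higher numbers for weaker inhibition. Compound 1 `Cc1ccc(F)cc1NC(=O)CN1CCN(c2nnc(Cc3ccccc3)c3ccccc23)CC1` gives 19200 nM. Compound 2 `O=C(CN1CCN(c2nnc(Cc3ccccc3)c3ccccc23)CC1)Nc1ccc(F)c(C(F)(F)F)c1` gives 760 nM, and compound 3 `O=C(CN1CCN(c2nnc(Cc3ccccc3)c3ccccc23)CC1)Nc1ccc(F)c(Cl)c1` gives 7360 nM. Compound 3 therefore stands second highest of the three numbers: the step of a 2.6-fold lower number from compound 1 to compound 3 (0.42 log units; beyond the scatter) is modest, whereas the step of a 9.7-fold higher number from compound 2 to compound 3 (0.99 log units; beyond the scatter) is larger.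

Compound 4 `O=C(CN1CCN(c2nnc(Cc3ccccc3)c3ccccc23)CC1)Nc1cccc(Br)c1` is the next candidate. Compared with compound 3, the change is 3-bromophenyl in place of 3-chloro-4-fluorophenyl on an amide-type nitrogen. Both recorded steps bear on this position. The step of a 25-fold lower number from compound 1 to compound 2 (1.40 log units; beyond the scatter) was large, and the step of a 9.7-fold higher number from compound 2 to compound 3 (0.99 log units; beyond the scatter) showed that even exchanging one group on this ring moves the number clearly. For the measured compounds named here, no measured pair, however, covers bromo in place of chloro or the loss of the fluoro, so the expectation rests on the two chloro- and fluoro-bearing neighbours. Compound 4 is estimated at 8000 nM, within 3000 nM to 22000 nM, meaning an expected step of a 1.1-fold higher number from compound 3 to compound 4 (0.04 log units; within the scatter) that need not exceed the scatter.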

Compound 4, half-maximal inhibitory concentration: 3880 nM
Estimate against measurement, compound 4: 2.1-fold (0.31 log units) above; low and high end bracket the measured number.
By their numbers in this assay, from the lowest: compound 2; then compounds 4 and 3 (each within the scatter of the next); then compound 1.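

In this assay the exchange of 3-chloro-4-fluorophenyl for 3-bromophenyl gives a 1.9-fold lower number from compound 3 to compound 4 (0.28 log units; within the scatter) and so separates the two rings by no real margin, which shows that a single bromo on this ring can stand in for the chloro and fluoro pair. The 3-bromophenyl group still sits clearly apart from the other two rings, with a 5.1-fold higher number from compound 2 to compound 4 (0.71 log units; beyond the scatter) on one side and a 4.9-fold lower number from compound 1 to compound 4 (0.69 log units; beyond the scatter) on the other. Compound 2, with its 4-fluoro-3-(trifluoromethyl)phenyl group, therefore remains the strongest of the four.

Bromo and the loss of the fluoro arrive together here, so what each contributes stays open, and a 3-chlorophenyl group on the same amide-type nitrogen would help to separate them. Nothing shown explains why these rings give different numbers.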